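This account rests on a few compounds, and the source may have more. Where it says the series, first, only, none or still open, it means among the compounds named here.

Compound 1 `Cc1ccc(S(=O)(=O)Nc2ccc(NS(=O)(=O)c3ccc(F)c(F)c3)cc2)cc1` is read in an assay for inhibition of liver carboxylesterase 1 (Homo sapiens), read by spectrophotometry; a higher number here means a weaker inhibitor, a lower number a stronger inhibitor. In this assay compound 1 gives > 100000 nM, which is a limit of the assay and not a number. Compound 3 `O=S(=O)(Nc1ccc(NS(=O)(=O)c2ccc(F)c(F)c2)cc1)c1ccccc1` differs from compound 1 by hydrogen in place of methyl on an aromatic carbon. In this assay compound 3 gives > 100000 nM, again a limit. The step that the two limits leave unreadable from compound 1 to compound 3 therefore cannot be read. Compound 2 `Cc1c(C)c(NS(=O)(=O)c2ccc(F)cc2)c(C)c(C)c1NS(=O)(=O)c1ccc(F)cc1` is the third member shown. In this assay compound 2 gives > 100000 nM, also a limit. Every value shown sits at the limit of > 100000 nM in this assay, at which 3 of the 3 values shown sit, so compound 1 stands where the whole series stands, with no readable step anywhere.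

Compound 4 `Cc1ccc(S(=O)(=O)Nc2ccc(NS(=O)(=O)c3ccc(F)cc3F)cc2)cc1` differs from compound 1 by 2,4-difluorophenyl in place of 3,4-difluorophenyl on a sulfonyl sulfur. Among the measured compounds shown here, no measured step bears on this change, since the only step is unreadable and all values sit at the limit. No step beyond the scatter is expected in this assay; the expected step is a step that the limit leaves unreadable from compound 1 to compound 4. Compound 4 is estimated at 150000 nM, within 30000 nM to 600000 nM, most likely reported once more as a limit.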

Compound 4, inhibition constant: > 100000 nM
Compound 4 gave a limit, no number; the forecaster's own chance of this, stated with the estimate: 85%; the middle value does not contradict the limit.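

In this assay compound 4 gives > 100000 nM, a limit and not a number, so no step from compound 1 to compound 4 can be read: the limit of > 100000 nM in this assay, at which 4 of the 4 values shown sit.

The compounds shown leave open which change to the shared core, if any, would give a readable value in this assay.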